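Swapping the benzoyl group on a gastric cancer cell series

A few compounds are considered here, and "the series" means these few. Any claim that something is new, unique, unknown or untested is made for them only; others in the source may bear on it.

Measured compounds:
compound 1 `CN(C(=O)NC(=O)c1ccc(Cl)cc1Cl)c1nc(C(F)(F)F)c(C(=O)N/N=C/c2cccc(C(F)(F)F)c2)s1` — 6.11 ug/mL
compound 2 `CN(C(=O)NC(=O)c1ccc(Cl)cc1Cl)c1nc(C(F)(F)F)c(C(=O)N/N=C/c2cc(C(F)(F)F)cc(C(F)(F)F)c2)s1` — > 100 ug/mL
compound 3 `CN(C(=O)NC(=O)c1ccc(Cl)c(Cl)c1)c1nc(C(F)(F)F)c(C(=O)N/N=C/c2ccc([N+](=O)[O-])cc2)s1` — 2.13 ug/mL

All three were tested in a functional assay on BCG823 cells (Homo sapiens) for inhibition, read by MTT assay, with a stated time of 72 h; on this read-out lower numbers stand for stronger inhibition and higher numbers for weaker inhibition. Compound 1 gives 6.11 ug/mL. For compound 2 the assay reports only a limit, > 100 ug/mL, so its actual number is not known. Compound 3 gives 2.13 ug/mL. Within the data shown here, the single step between two compounds that differ in one place is an at least 16-fold higher number from compound 1 to compound 2 (1.21 log units; beyond the scatter); this concerns the hydrazone end of the shared core, and the value for compound 2 is recorded as the limit of > 100 ug/mL in this assay, at which 1 of the 3 values shown sits. Compound 3 differs from both others in more than one place, so its value can only be noted, not read as a step.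

Compound 4 `CN(C(=O)NC(=O)c1ccc(C(F)(F)F)cc1)c1nc(C(F)(F)F)c(C(=O)N/N=C/c2cc(C(F)(F)F)cc(C(F)(F)F)c2)s1` has not been measured. It differs from compound 2 at the other end of the shared core: 4-(trifluoromethyl)phenyl in place of 2,4-dichlorophenyl on a carbonyl carbon. Among the measured compounds shown here, no measured pair shows this exchange, so nothing among the measured steps speaks for or against it. Compound 2 stands at the limit of the assay, and a compound built on it with an untested change is expected to stay near that limit. Compound 4 is therefore estimated at 100 ug/mL, with a range from 30 ug/mL to 300 ug/mL. The expected step is a number no higher from compound 2 to compound 4 (the limit leaves the size open), which is no change beyond the scatter.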

Compound 4, half-maximal inhibitory concentration: 1.77 ug/mL
Compound 4: middle estimate off by 56-fold (1.75 log units), on the high side, outside the stated range (below it).
By their numbers in this assay, from the lowest: compounds 4 and 3 (each within the scatter of the next); then compound 1. At a limit, above all of these: compound 2.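

The benzoyl end of the shared core now has a readable step of its own, and a large one: in this assay, 4-(trifluoromethyl)phenyl in place of 2,4-dichlorophenyl on a carbonyl carbon gives an at least 56-fold lower number from compound 2 to compound 4 (1.75 log units; beyond the scatter). Among these compounds, until now, the only readable step lay at the hydrazone end, so this result shows that the group on this carbonyl carbon can decide whether a compound with the hydrazone end of compound 2 reads as active or sits out of range, since compound 4 keeps that hydrazone end unchanged. For compound 2 the assay gives only a limit, so the step has a lower bound and no exact size: the limit of > 100 ug/mL in this assay, at which 1 of the 4 values shown sits.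

This one exchange removes both chlorines and adds a trifluoromethyl group, and it cannot tell which of these changes matters, or whether the same exchange would work with the other hydrazone ends seen here. A plain phenyl, a 4-chlorophenyl or a 4-methoxyphenyl on the same carbonyl carbon would help to separate these possibilities, while an amine or a carboxylic acid on that ring remains an open question.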